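Hydroxyethylphenyl in place of methylimidazolyl on a shared core

This account rests on a few compounds, and the source may have more. Where it says the series, first, only, none or still open, it means among the compounds named here.

Compound 1, `CCCC[S+]([O-])c1sc2nc(-c3nccs3)cc(-c3ccc(CO)cc3)c2c1N`: in an assay for inhibition of 15-hydroxyprostaglandin dehydrogenase [NAD(+)] (Homo sapiens), read by fluorescence, with a stated time of 15 min, in the presence of a further agent that is not named here (a lower number here means a stronger inhibitor, a higher number a weaker inhibitor), compound 1 gives 2.5 nM.
Compound 2, `CCCC[S+]([O-])c1sc2nc(-c3nccs3)cc(-c3cnc(C)[nH]3)c2c1N`: in this assay compound 2 gives 2.3 nM.

On the numbers shown, compound 2 and compound 1 sit within the scatter of each other; the step of a 1.1-fold lower number from compound 1 to compound 2 (0.04 log units; within the scatter) is too small to separate them, so neither can be called the stronger inhibitor.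

Compound 3, `CCCC[S+]([O-])c1sc2nc(-c3nccs3)cc(-c3ccc(CCO)cc3)c2c1N`, has not yet been measured. It differs from compound 2 in one place: 4-(2-hydroxyethyl)phenyl in place of 2-methyl-1H-imidazol-5-yl on an aromatic carbon. Among the measured compounds shown here, only one measured step bears on this change, and it runs the other way: a 1.1-fold lower number from compound 1 to compound 2 (0.04 log units; within the scatter) exchanged 4-(hydroxymethyl)phenyl for 2-methyl-1H-imidazol-5-yl without a shift beyond the scatter. Compound 3 carries 4-(2-hydroxyethyl)phenyl, which matches the group of compound 1 except for the longer hydroxyalkyl chain. Since the measured exchange between these two ring types left the number where it was, the reverse exchange is expected to behave alike, and the step of a 1.1-fold higher number from compound 2 to compound 3 (0.05 log units; within the scatter) is expected to stay within the scatter in this assay.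

Compound 3 is therefore estimated at 2.6 nM in this assay, with a range from 1 nM to 7 nM.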

Compound 3, half-maximal inhibitory concentration: 2.9 nM
The estimate for compound 3 lay 1.1-fold (0.05 log units) below the measured number, within the range that was stated.
By their numbers in this assay, from the lowest: compounds 2, 1 and 3 (each within the scatter of the next).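

In this assay, the step of a 1.3-fold higher number from compound 2 to compound 3 (0.10 log units; within the scatter) shows that this position, on an aromatic carbon opposite the ring nitrogen, accepts the larger 4-(2-hydroxyethyl)phenyl, with 9 heavy atoms, in place of 2-methyl-1H-imidazol-5-yl, with 6, without a shift beyond the scatter. The step of a 1.2-fold higher number from compound 1 to compound 3 (0.06 log units; within the scatter) adds what the earlier pair could not show: on the phenyl ring, 2-hydroxyethyl in place of hydroxymethyl also stays within the scatter, so this chain extension does not separate the compounds. No measurement offered here accounts for why these three groups read alike.

The compounds shown leave open how far this tolerance extends, since each of the three groups stays close to the same number and none marks a limit at this position. Whether a plain phenyl without the hydroxyalkyl chain, a longer chain such as 3-hydroxypropyl, or a terminal amine or carboxylic acid in place of the hydroxy would stay within the scatter remains unanswered.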